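A Basic Amine Side Chain Replaces the Urea of Compound 1

The source may hold more compounds than are shown below. What is called first, only, known or untested is meant among the compounds shown, and "the series" means these compounds.

Compound 1 `CCNC(=O)Nc1cccc2c1CN(C)CC2c1ccccc1` carries an ethylamino group on the carbonyl carbon of its side chain. In a functional assay on the whole organism for inhibition of sodium-dependent dopamine transporter (Mus musculus) (on this read-out higher numbers stand for an effect only at larger amounts of compound and lower numbers for an effect already at smaller amounts), compound 1 gives > 80 mg/kg, which is a limit of the assay and not a number. Compound 2 `CCCNC(=O)Nc1cccc2c1CN(C)CC2c1ccccc1` likewise reaches only a limit in this assay, at > 120 mg/kg. Compound 3 `CCNCCC(=O)Nc1cccc2c1CN(C)CC2c1ccccc1` gives 190 mg/kg in this assay. The steps among these three, a step that the two limits leave unreadable from compound 1 to compound 2, a step that the limit leaves unreadable from compound 1 to compound 3 and a step that the limit leaves unreadable from compound 2 to compound 3, cannot be read in size; the limit of > 120 mg/kg in this assay, at which 1 of the 3 values shown sits, and the limit of > 80 mg/kg in this assay, at which 1 of the 3 values shown sits, leave them open.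

Compound 4 `CN1Cc2c(NC(=O)CN3CCCC3)cccc2C(c2ccccc2)C1` differs from compound 1 by (pyrrolidin-1-yl)methyl in place of ethylamino on a carbonyl carbon. Among the compounds with values here, no measured step matches this change. Within the data shown here, compound 3, the one measured compound whose side chain holds a basic nitrogen on the carbonyl side, gives 190 mg/kg, so a similarly weak effect is expected for compound 4. Compound 4 is therefore estimated to give 150 mg/kg, in a range from 60 mg/kg to 400 mg/kg. The expected step would read a step that the limit leaves unreadable from compound 1 to compound 4, with the value of compound 1 itself being only a limit.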

Compound 4, dose for half-maximal effect: 45 mg/kg
Estimate against measurement, compound 4: 3.3-fold (0.52 log units) above; the measured number lies below the stated range.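

Within the data shown here, compound 4 is the first compound here with a ring in the side chain on the carbonyl carbon, and its number can be read against all three earlier compounds. In this assay, among these compounds, the only comparison between two actual numbers is a 4.2-fold lower number from compound 3 to compound 4 (0.63 log units; beyond the scatter), so pyrrolidin-1-yl in place of (ethylamino)methyl on a saturated chain carbon bound to a carbonyl carbon gives a change beyond the scatter. The other two comparisons start from limits and give only floors, an at least 1.7-fold lower number from compound 1 to compound 4 (0.24 log units; that floor lies within the scatter) and an at least 2.6-fold lower number from compound 2 to compound 4 (0.42 log units; beyond the scatter), the first within the scatter and the second beyond it.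

The step from compound 3 swaps the open ethylamino chain for the ring and also shortens the chain, so the two changes cannot be told apart. The open-chain (diethylamino)methyl group or the larger-ringed (piperidin-1-yl)methyl group at this place would help to separate them.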